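Swapping a Hydroxy for a Carbamoyl in Compound 2

The source may hold more compounds than are shown below. What is called first, only, known or untested is meant among the compounds shown, and "the series" means these compounds.

Of the compounds shown here, three with a shared core have been tested in an assay on isolated protein for inhibition of Matrilysin (Homo sapiens), read by fluorescence, with a stated time of 15 min; on this read-out lower numbers stand for stronger inhibition and higher numbers for weaker inhibition. Compound 1 `CC(C)C[C@H](NC(=O)[C@H](C)NC(=O)CC[C@H](NS(=O)(=O)c1ccc(Cl)c(C(F)(F)F)c1)C(=O)O)C(=O)N[C@@H](C)C(N)=O` gives 1700 nM. Compound 2 `CSCC[C@H](NC(=O)[C@H](CC(C)C)NC(=O)[C@H](CO)NC(=O)CC[C@H](NS(=O)(=O)c1ccc(Cl)c(C(F)(F)F)c1)C(=O)O)C(N)=O` gives 5700 nM, and compound 3 `O=C(O)[C@H](CCc1ccccc1)NS(=O)(=O)c1ccc(Cl)c(C(F)(F)F)c1` gives 6100 nM. Compound 2 stands second highest of the three: its value and that of compound 3 lie within the usual scatter, while compound 1 sits beyond the scatter at a lower number, meaning stronger inhibition. Compound 4 `CSCC[C@H](NC(=O)[C@H](CC(C)C)NC(=O)[C@H](CC(N)=O)NC(=O)CC[C@H](NS(=O)(=O)c1ccc(Cl)c(C(F)(F)F)c1)C(=O)O)C(N)=O` has not yet been measured in this assay. It differs from compound 2 by carbamoyl in place of hydroxy on a saturated chain carbon, two bonds along the chain from an amide-type nitrogen and a carbonyl carbon. Among the measured compounds shown here, no measured pair shows this exact change, so the step is expected to be small, a 1.1-fold lower number from compound 2 to compound 4 (0.06 log units; within the scatter), staying within the scatter. Compound 4 is therefore estimated at 5000 nM, with a range from 2000 nM to 14000 nM.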

Compound 4, half-maximal inhibitory concentration: 7500 nM
Compound 4: middle estimate off by 1.5-fold (0.18 log units), on the low side, within the range that was stated.
By their numbers in this assay, from the lowest: compound 1; then compounds 2, 3 and 4 (each within the scatter of the next).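

In this assay, carbamoyl in place of hydroxy on this saturated chain carbon gives a 1.3-fold higher number from compound 2 to compound 4 (0.12 log units; within the scatter) and so makes no clear difference. Among the compounds shown here, this is the first comparison here of two compounds that differ in one place, and it shows that hydroxymethyl and carbamoylmethyl cannot be told apart at this position in this test. No outside data on hand bear on this result.

From the compounds shown here alone, whether an amine, a carboxylic acid or a longer chain on this carbon would shift the number beyond the scatter remains open.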